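Bromoacetamide in Place of the Dienamide on Compound 2

The source may hold more compounds than are shown below. What is called first, only, known or untested is meant among the compounds shown, and "the series" means these compounds.

Measured compounds:
compound 1 `COc1ccc(CNc2cc(OC)c(OC)c(OC)c2)cc1Cl` — 47800 nM
compound 2 `C/C=C/C=C/C(=O)N(Cc1ccc(OC)c(O)c1)c1cc(OC)c(OC)c(OC)c1` — 180 nM

In a functional assay on KYSE-450 cells (Homo sapiens) for inhibition, read by MTT assay, with a stated time of 48 h (on this read-out higher numbers stand for weaker inhibition and lower numbers for stronger inhibition), compound 2 gives 180 nM, the lowest of the two numbers measured. Compound 1 gives 47800 nM in this assay, a far higher number, well beyond the usual scatter; the two compounds differ in several places, so the pair shows only that an acylated amine on the shared core sits far below the free benzylamine with a chloro-methoxy ring.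

Compound 3 `COc1ccc(CN(C(=O)CBr)c2cc(OC)c(OC)c(OC)c2)cc1O` is not yet measured. It differs from compound 2 in one place:

bromomethyl in place of penta-1,3-dien-1-yl on a carbonyl carbon

Within the data shown here, since no step between measured compounds maps this change, the direction must be a guess resting on compound 2 alone. The account expects a moderate rise in the number, beyond the scatter, because the low value of compound 2 in this assay, 180 nM, belongs to the penta-1,3-dien-1-yl carbonyl that leaves. The expected step of a 5.6-fold higher number from compound 2 to compound 3 (0.74 log units; beyond the scatter) is thus toward weaker inhibition. Compound 3 is estimated at 1000 nM, with a range from 150 nM to 8000 nM.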

Compound 3, half-maximal inhibitory concentration: 120 nM
Estimate against measurement, compound 3: 8.3-fold (0.92 log units) above; measured number outside the range, below it.
By their numbers in this assay, from the lowest: compounds 3 and 2 (each within the scatter of the next); then compound 1.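

In this assay, replacing the penta-1,3-dien-1-yl on the carbonyl carbon with bromomethyl leaves the number within the scatter (a 1.5-fold lower number from compound 2 to compound 3 (0.18 log units; within the scatter)). On this evidence, a low number at this position does not depend on the penta-1,3-dien-1-yl group: bromomethyl has 2 heavy atoms and no double bonds outside aromatic rings, while the group that leaves has 5 heavy atoms and 2 such double bonds, and compounds 2 and 3 cannot be told apart in this assay. Nothing shown explains why two such different groups give values within the scatter of each other.

What the bromine contributes stays open, since the compounds shown do not include a plain methyl, a chloromethyl or a hydroxymethyl on the same carbonyl carbon. They also leave open how a longer saturated chain, a phenyl ring or an amine at this place would read, and so whether this position accepts many groups or only the two seen here.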